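Swapping the halogenated phenyl ring on a shared core

A few compounds are considered here, and "the series" means these few. Any claim that something is new, unique, unknown or untested is made for them only; others in the source may bear on it.

Compound 1 `O=C1CSC(c2cccc(Cl)c2)N1CCN1CCCCC1` is the starting point. In an ADME assay on Vero cells (Chlorocebus sabaeus) for cytotoxicity, read by neutral red uptake, tested at 12.3 ug/mL (on this read-out lower numbers stand for a stronger effect and higher numbers for a weaker effect at the one concentration tested), compound 1 gives 100%. Its closest neighbour, compound 2 `COc1ccccc1C1SCC(=O)N1CCN1CCCCC1`, gives 100% in this assay, and the two values agree within the usual scatter. Compound 3 `O=C1CSC(c2ccc(F)cc2)N1CCN1CCCCC1` has not yet been tested. It differs from compound 1 in one place: 4-fluorophenyl in place of 3-chlorophenyl on a saturated ring carbon. Because compound 2 shows 100% in this assay and compound 1 shows 100%, the step is expected to be none beyond the scatter: no change at the digits printed from compound 1 to compound 3 (within the scatter). Compound 3 is therefore estimated at 100% in this assay, with a likely range from 85% to 100%.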

Compound 3, a percentage reported as activity, at one concentration (the size of the read-out at that concentration, not a potency): 100%
Compound 3: the middle estimate sits on the measured number at the digits printed, within the range that was stated.
By their numbers in this assay, from the lowest: compounds 1, 2 and 3 (each within the scatter of the next).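

Among the compounds shown here, replacing 3-chlorophenyl with 4-fluorophenyl on the saturated ring carbon gives no change at the digits printed from compound 1 to compound 3 (within the scatter) in this assay and is the first readable step at this position. It changes both the halogen and where it sits on the phenyl ring, yet the read-out at this one concentration does not separate the two compounds. No measured evidence explains this result. The compounds shown leave open whether an amine, a carboxylic acid or a longer chain in place of the phenyl ring would shift this read-out.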